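The compounds below may be only part of what the source reports. "The series", "measured", "known", "first", "only" and "open" are said of these compounds alone.

Measured so far in a functional assay on DU-145 cells (Homo sapiens) for cytotoxicity, read by sulforhodamine B assay, with a stated time of 48 h; a higher number here means a weaker inhibitor, a lower number a stronger inhibitor:
compound 1 `CC(=O)OC[C@H]1O[C@@H](n2cc(CN3C(=O)/C(=C\c4ccccc4)c4ccccc43)nn2)[C@H](OC(C)=O)[C@@H](OC(C)=O)[C@@H]1OC(C)=O` gives 24100 nM
compound 2 `CC(=O)OC[C@H]1O[C@@H](n2cc(CN3C(=O)/C(=C/c4ccccc4)c4ccccc43)nn2)[C@H](OC(C)=O)[C@@H](OC(C)=O)[C@@H]1OC(C)=O` gives 22800 nM
compound 3 `CC(=O)OC[C@H]1O[C@@H](n2cc(CN3C(=O)/C(=C/c4ccco4)c4ccccc43)nn2)[C@H](OC(C)=O)[C@@H](OC(C)=O)[C@@H]1OC(C)=O` gives 10000 nM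

Compound 1 carries the highest number of the three, though compound 2 lies within the scatter of it: a 1.1-fold lower number from compound 1 to compound 2 (0.02 log units; within the scatter), which fits (the fact that compounds 1 and 2 differ only in the configuration as drawn). Compound 3 is the only one set apart beyond the scatter, through a 2.3-fold lower number from compound 2 to compound 3 (0.36 log units; beyond the scatter), a modest step.

Compound 4 `CCC/C=C1\C(=O)N(Cc2cn([C@@H]3O[C@H](COC(C)=O)[C@@H](OC(C)=O)[C@H](OC(C)=O)[C@H]3OC(C)=O)nn2)c2ccccc21` is not yet measured. It differs from compound 1 in one place: propyl in place of phenyl on a double-bonded chain carbon bound to a double-bonded ring carbon. Among the compounds with values here, the one measured step at that same place is the exchange of phenyl for furan-2-yl, a 2.3-fold lower number from compound 2 to compound 3 (0.36 log units; beyond the scatter); the geometry step a 1.1-fold lower number from compound 1 to compound 2 (0.02 log units; within the scatter) is within the scatter. Neither step involves a propyl, so a chain in place of the aromatic group has no direct precedent among these three compounds. Within the data shown here, with the narrow spread of the numbers so far, the expected step from compound 1 to compound 4 is about none beyond the scatter, a 1.0-fold higher number from compound 1 to compound 4 (0.02 log units; within the scatter), the range leaving room for a modest move in either direction. Compound 4 is thus estimated at 25000 nM in this assay, between 10000 nM and 60000 nM.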

Compound 4, half-maximal inhibitory concentration: 26600 nM
Compound 4: the middle estimate sits 1.1-fold (0.03 log units) below what was measured, and the stated range covers the measured number.
By their numbers in this assay, from the lowest: compound 3; then compounds 2, 1 and 4 (each within the scatter of the next).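

In this assay, a phenyl ring is not needed on the double-bonded chain carbon bound to a double-bonded ring carbon to keep a number of this size: propyl in its place gives a 1.1-fold higher number from compound 1 to compound 4 (0.04 log units; within the scatter). The place is still not indifferent to its group, as furan-2-yl in place of phenyl gives a 2.3-fold lower number from compound 2 to compound 3 (0.36 log units; beyond the scatter), so of the two exchanges shown, only the one to furan-2-yl goes beyond the scatter. No measured finding at hand accounts for either outcome.

From the compounds shown here alone, whether a longer chain such as hexyl, or a propyl chain ending in an amine or a carboxylic acid, would stay within the scatter of compound 1 remains open. Also open is whether double-bond geometry matters with propyl or furan-2-yl, as only the phenyl pair is shown in both geometries.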